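Halogen versus Nitrile on the Phenyl of a Triazole Series

This account rests on a few compounds, and the source may have more. Where it says the series, first, only, none or still open, it means among the compounds named here.

Compound 1 `CC1(C)[C@H]2CC[C@]1(C)N(Cc1cn(-c3cccc(F)c3)nn1)C(=O)C2` in a functional assay on LoVo cells (Homo sapiens) for inhibition, read by MTT assay, with a stated time of 24 h (on this read-out higher numbers stand for weaker inhibition and lower numbers for stronger inhibition), compound 1 gives 90 nM.
Compound 2 `CC1(C)[C@H]2CC[C@]1(C)N(Cc1cn(-c3cccc(C#N)c3)nn1)C(=O)C2` in this assay compound 2 gives 320 nM.

For the measured compounds named here, compound 2 stands with the highest of the two numbers; the only measured step, a 3.6-fold higher number from compound 1 to compound 2 (0.55 log units; beyond the scatter), lies beyond the scatter. Compound 3 `CC1(C)[C@H]2CC[C@]1(C)N(Cc1cn(-c3ccc(Cl)cc3)nn1)C(=O)C2` differs from compound 2 in one place: 4-chlorophenyl in place of 3-cyanophenyl on an aromatic nitrogen. Going by the values given here, no measured step covers this exact exchange; the step from compound 1 shows that changing the phenyl substituent can move this number modestly. A halogen returns with compound 3, so a lower number is expected, a 2.5-fold lower number from compound 2 to compound 3 (0.39 log units; beyond the scatter). The estimate for compound 3 is 130 nM, within 45 nM to 400 nM.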

Compound 3, half-maximal inhibitory concentration: 160 nM
Compound 3: middle estimate off by 1.2-fold (0.09 log units), on the low side; the measured number falls inside the stated range.
By their numbers in this assay, from the lowest: compounds 1, 3 and 2 (each within the scatter of the next, the first and the last beyond it).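

The 4-chlorophenyl group sits close to both neighbours in this assay: a 2.0-fold lower number from compound 2 to compound 3 (0.30 log units; within the scatter) and a 1.8-fold higher number from compound 1 to compound 3 (0.25 log units; within the scatter), and both steps lie within the scatter. Only compound 1 and compound 2 stand beyond the scatter of each other, so a halogen on the phenyl does not clearly separate from a nitrile across these three compounds. No supporting measurement here accounts for these numbers. Open, going by these compounds, is whether chlorine and fluorine would differ on the same phenyl carbon, since compound 3 changes both the group and its place. Also open, on these data alone, is how an amine or a carboxylic acid on the phenyl would read.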